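Removing a Hydroxymethyl Group: Expected Effect on Cell Tolerance

The compounds below may be only part of what the source reports. "The series", "measured", "known", "first", "only" and "open" are said of these compounds alone.

Compound 1 `CC(C)(O)c1cc2c(-c3ccccc3CO)nccc2[nH]1` carries a hydroxymethyl group on its aromatic six-membered ring. Compound 3 `CC(C)(O)c1cc2c(-c3ccccc3)nccc2[nH]1` is the same molecule with that group gone: the change is hydrogen in place of hydroxymethyl on an aromatic carbon. The assay of interest is an ADME assay on U2OS cells (Homo sapiens) for cytotoxicity; a higher number here means that more compound is tolerated, a lower number that less compound is tolerated. For compound 1 the result in this assay is "not determined" (no result reported), so there is no number to start from. For the measured compounds named here, the only measured reference is compound 2 `CC(C)(O)c1cc2c(-c3cc(C(F)(F)F)cc(C(F)(F)F)c3)nccc2[nH]1`, which shares the core and bears two trifluoromethyl groups on its aromatic ring; in this assay compound 2 gives 59800 nM, a value indicating that the cells tolerate a good deal of it. Since compound 1 has no number, the size of the step to compound 3 cannot be computed, and nothing in the data suggests a shift beyond the usual scatter. Compound 3 is therefore estimated to give about 70000 nM in this assay, with a likely range from 25000 nM to 200000 nM.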

Compound 3, half-maximal cytotoxic concentration: 22200 nM
Compound 3: the middle estimate sits 3.2-fold (0.50 log units) above what was measured, and the stated range ends above it.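

For the compounds shown here, with no number for compound 1 in this assay, no step from it to compound 3 can be read. No further evidence bears on this result. The compounds shown leave open whether replacing hydroxymethyl with hydrogen changes how much compound the cells tolerate.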